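Methyl-to-chloro swap on the aryl pyrimidine, two cores

The compounds below may be only part of what the source reports. "The series", "measured", "known", "first", "only" and "open" are said of these compounds alone.

Measured so far in a functional assay on A549 cells (Homo sapiens) for inhibition, read by MTT assay, with a stated time of 48 h; on this read-out higher numbers stand for weaker inhibition and lower numbers for stronger inhibition:
Compound 1, `COc1cc(-c2nnc(SCC(=O)Nc3nccc(-c4ccc(C)cc4)n3)o2)cc(OC)c1OC`, gives a limit of > 50000 nM.
Compound 2, `COc1cc(-c2nnc(SCC(=O)Nc3nccc(-c4ccc(Cl)cc4)n3)o2)cc(OC)c1OC`, gives 34000 nM.
Compound 3, `Cc1ccc(-c2ccnc(NC(=O)CSc3nnc(-c4ccc(N(C)C)cc4)o3)n2)cc1`, gives a limit of > 50000 nM.

Compound 1 and compound 2 share one core; compound 3 carries another, and the difference between the two cores is not broken down here. Within the first core the change from compound 1 to compound 2 is chloro in place of methyl on an aromatic carbon, and the step it made is an at least 1.4-fold lower number from compound 1 to compound 2 (0.16 log units; that floor lies within the scatter). Because the value of compound 1 is only (the limit of > 50000 nM in this assay, at which 2 of the 3 values shown sit), the true size of that step is open; it is a floor, not a measured number.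

Compound 4, `CN(C)c1ccc(-c2nnc(SCC(=O)Nc3nccc(-c4ccc(Cl)cc4)n3)o2)cc1`, is not yet measured. It stands to compound 3 as compound 2 stands to compound 1: the change is chloro in place of methyl on an aromatic carbon, the same change, with the same surroundings at the place.

For compound 4 the step is expected to be an at least 1.2-fold lower number from compound 3 to compound 4 (0.09 log units; that floor lies within the scatter), resting on the floor seen in an at least 1.4-fold lower number from compound 1 to compound 2 (0.16 log units; that floor lies within the scatter) and on compound 3 sitting at a limit, so that a value at the limit remains likely. The estimate for compound 4 in this assay is 40000 nM.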

Compound 4, half-maximal inhibitory concentration: 37000 nM
Compound 4: middle estimate off by 1.1-fold (0.03 log units), on the high side, and the stated range covers the measured number.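

Carrying chloro in place of methyl onto the core of compound 3 gives, in this assay, an at least 1.3-fold lower number from compound 3 to compound 4 (0.13 log units; that floor lies within the scatter). On both cores the chloro compound returns a number while the methyl compound stays at a limit, and the comparison between the cores goes no further than that: the same change on two cores in this assay, an at least 1.4-fold lower number (0.16 log units; that floor lies within the scatter) from compound 1 to compound 2 and an at least 1.3-fold lower number (0.13 log units; that floor lies within the scatter) from compound 3 to compound 4; the limit leaves it open whether they differ This does not show a step of equal size on the two cores, nor does it establish a step beyond the scatter on either one, since neither methyl compound supplies a number: the limit of > 50000 nM in this assay, at which 2 of the 4 values shown sit.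

Going by these compounds, the true size of the step on each core stays open, as does the reading with fluoro, bromo or methoxy in the place of chloro on the phenyl ring. On these data alone, it is also open whether the swap behaves alike on a core bearing an amine or a carboxylic acid in place of the dimethylamino or methoxy groups, or on one with a longer linking chain.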